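A few compounds are considered here, and "the series" means these few. Any claim that something is new, unique, unknown or untested is made for them only; others in the source may bear on it.

Measured so far:
compound 1 (`Cc1cc(NCc2ccccn2)n2ncc(Br)c2n1`): 89300 nM
compound 2 (`Cc1cc(NCc2ncc[nH]2)n2nc(C)c(-c3ccccc3)c2n1`): < 5000 nM

Of the compounds shown here, two have been measured in a physicochemical assay for solubility, read by HPLC, using the shake flask method, measured as kinetic solubility, with a stated time of 2 h, at pH 7.4; on this read-out lower numbers stand for lower solubility and higher numbers for higher solubility. Compound 1 gives 89300 nM, which is the only number shown in this set. For compound 2 the assay returns < 5000 nM, a limit rather than a number, and this is the point described in the limit of < 5000 nM in this assay, at which 1 of the 2 values shown sits. Among the compounds with values here, with only a number and a limit in hand, no step between measured compounds can be drawn, so compound 1 stands alone as the one compound with a definite read-out.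

Compound 3 (`Cc1cc(NCc2ccccn2)n2ncc(-c3ccc(F)cc3F)c2n1`) has not been measured. It differs from compound 1 in one place: 2,4-difluorophenyl in place of bromo on an aromatic carbon. Within the data shown here, no measured pair in this set shows what such a change does in this assay, so the size of the step cannot be taken from the data. The account nonetheless expects solubility to fall, with an estimated step of a 6.0-fold lower number from compound 1 to compound 3 (0.77 log units; beyond the scatter), a move expected to lie beyond the usual scatter. For compound 3 the estimated value in this assay is 15000 nM, within a range from 3000 nM to 60000 nM.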

Compound 3, solubility: < 5000 nM
Compound 3 ended at the assay's limit; the forecaster's own chance of this, stated with the estimate: 30%; middle value at least 3.0-fold (0.47 log units) away from the limit.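

Within the data shown here, this is the first step in the set that can be read between two compounds differing in one place. On an aromatic carbon of the five-membered aromatic ring with 2 nitrogen, 2,4-difluorophenyl in place of bromo gives an at least 17-fold lower number from compound 1 to compound 3 (1.25 log units; beyond the scatter) in this assay, and the change brings in a six-membered aromatic ring of carbon only while adding no hydrogen-bond donor, no hydrogen-bond acceptor and no net charge. The read-out of compound 3 is a limit of the assay and not a number, so this step gives only a minimum size, and compound 3 is now one of the values resting there: the limit of < 5000 nM in this assay, at which 2 of the 3 values shown sit.

The compounds shown leave open whether the fall goes with the aromatic ring itself or with its two fluorines, which plain phenyl at this carbon would separate. They also leave open what a small group such as methyl, or a group carrying an amine or a carboxylic acid, would give at this place on the core of compound 1.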